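The source may hold more compounds than are shown below. What is called first, only, known or untested is meant among the compounds shown, and "the series" means these compounds.

Measured compounds:
Compound 1 `CCCc1c(COc2ccc(C(=O)CCC(=O)O)cc2)ccc(C(C)=O)c1O` gives 6.75 in a functional assay on ileum (Cavia porcellus) with cysteinyl leukotriene receptor (Homo sapiens) as the target; a lower number here means a less potent compound, a higher number a more potent compound, by a factor of ten per unit of this negative logarithm.
Compound 2 `CCCc1c(COc2ccc(C(=O)C(C)(C)Cc3nnn[nH]3)cc2)ccc(C(C)=O)c1O` gives 6.93 in this assay.

For the measured compounds named here, of these two numbers, compound 2 holds the upper one, but the only measured step, a number 0.18 log units higher from compound 1 to compound 2 (within the scatter), is small. Compound 3 `CCCc1c(COc2ccc(C(=O)CC(C)(C)CC(=O)O)cc2)ccc(C(C)=O)c1O` differs from compound 2 by 2-(carboxymethyl)-2-methylpropyl in place of 1-((1H-tetrazol-5-yl)methyl)-1-methylethyl on a carbonyl carbon. That one step replaced a carboxylic acid chain with a tetrazole group and changed little, so swapping back to a carboxylic acid chain is expected to move this assay by no more than the scatter, in either direction. Compound 3 is therefore estimated at 6.8, with a range of 6.3 to 7.3, meaning an expected step of a number 0.13 log units lower from compound 2 to compound 3 (within the scatter).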

Compound 3, negative logarithm of the antagonist equilibrium constant: 7.73
Compound 3: middle estimate off by 0.93 log units, on the low side; measured number above the stated range.
By their numbers in this assay, from the lowest: compounds 1 and 2 (each within the scatter of the next); then compound 3.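

On this carbonyl carbon, the two end groups are not interchangeable, even though the first pair suggested they might be: in this assay, 2-(carboxymethyl)-2-methylpropyl in place of 1-((1H-tetrazol-5-yl)methyl)-1-methylethyl gives a number 0.80 log units higher from compound 2 to compound 3 (beyond the scatter). Keeping the carboxylic acid, 1-(carboxymethyl)-1-methylethyl in place of carboxymethyl on a saturated chain carbon bound to a carbonyl carbon gives a number 0.98 log units higher from compound 1 to compound 3 (beyond the scatter). No measurement available here explains this rise. Going by these compounds, whether the methyl groups or the added chain length matter more stays open, as does the effect of an amide in place of the carboxylic acid.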